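Replacing the phenol ring with a dimethylisoxazole

The compounds below may be only part of what the source reports. "The series", "measured", "known", "first", "only" and "open" are said of these compounds alone.

Measured compounds:
- compound 1, `CCOc1ccc(-c2cccc(CNc3ccc(OCC(=O)O)c(F)c3)c2)c(C)c1`: 11.6 nM
- compound 2, `Cc1cc(O)ccc1-c1cccc(CNc2ccc(OCC(=O)O)c(F)c2)c1`: 69.6 nM

Among the measured compounds shown here, in a functional assay on CHO cells for agonist activity at Free fatty acid receptor 1 (Homo sapiens), read by FLIPR and calcium flux (on this read-out lower numbers stand for an effect already at smaller amounts and higher numbers for an effect only at larger amounts of compound), compound 2 gives the higher of the two numbers; the only measured step, a 6.0-fold higher number from compound 1 to compound 2 (0.78 log units; beyond the scatter), separates it from compound 1. Compound 3, `Cc1noc(C)c1-c1cccc(CNc2ccc(OCC(=O)O)c(F)c2)c1`, differs from compound 2 by 3,5-dimethyl-1,2-oxazol-4-yl in place of 4-hydroxy-2-methylphenyl on an aromatic carbon. For the measured compounds named here, no measured step touches this exchange of one aromatic ring for another, so the expectation rests on no direct precedent and carries a wide range. Compound 3 is expected to stay near compound 2, with a step of a 1.4-fold lower number from compound 2 to compound 3 (0.14 log units; within the scatter) not clearly beyond the scatter, estimated at 50 nM within 10 nM to 250 nM.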

Compound 3, half-maximal effective concentration: 225 nM
Estimate against measurement, compound 3: 4.5-fold (0.65 log units) below; the measured number falls inside the stated range.
By their numbers in this assay, from the lowest: compound 1; then compound 2; then compound 3.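

Among the compounds shown here, at this aromatic carbon, the earlier compounds changed only a group on the ring, whereas here the whole ring is exchanged: in this assay, 3,5-dimethyl-1,2-oxazol-4-yl gives a 3.2-fold higher number from compound 2 to compound 3 (0.51 log units; beyond the scatter), and against the ethoxy-bearing ring it gives a 19-fold higher number from compound 1 to compound 3 (1.29 log units; beyond the scatter). Both steps lie beyond the scatter, so this five-membered ring matches neither six-membered ring on this read-out. No measurement at hand explains these steps.

From the compounds shown here alone, whether the ring size or the absence of the hydroxy or ethoxy group matters more stays open, as does how a pyridine ring would fare at this carbon.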